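The source may hold more compounds than are shown below. What is called first, only, known or untested is meant among the compounds shown, and "the series" means these compounds.

Of the compounds shown here, three built on one shared core have been tested in a toxicity assay on THP-1 cells (Homo sapiens) for inhibition; a lower number here means that less compound is tolerated, a higher number that more compound is tolerated. Compound 1 `Cc1ccccc1-c1cnc(NC(=O)c2ccc(F)cc2)n1C` reaches only a limit of the assay, > 50000 nM. Compound 2 `COc1cccc(-c2cnc(NC(=O)c3ccc(F)cc3)n2C)c1` likewise gives only a limit, > 100000 nM. Between these two the step is a step that the two limits leave unreadable from compound 1 to compound 2. Compound 3 `COc1ccc(-c2cnc(NC(=O)c3cccc([N+](=O)[O-])c3)n2C)cc1` also shows only a limit, > 100000 nM, so it stands at the limit of > 100000 nM in this assay, at which 2 of the 3 values shown sit. Compound 4 `COc1ccc(-c2cnc(NC(=O)c3cccc(F)c3)n2C)cc1` differs from compound 3 by fluoro in place of nitro on an aromatic carbon. For the measured compounds named here, no measured step covers this change, and every value shown is a limit, so no readable size is available; the expected step is therefore a number no higher from compound 3 to compound 4 (the limit leaves the size open), nothing beyond scatter. Compound 4 is expected at 100000 nM, with a range from 50000 nM to 200000 nM, most likely again reported only as a limit.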

Compound 4, half-maximal cytotoxic concentration: > 100000 nM
Compound 4: a limit, no number; the forecaster's own chance of this, stated with the estimate: 85%; the middle value sits exactly at the limit.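

Compound 3 and compound 4 both give only a limit of the assay, so the size of the step from nitro to fluoro cannot be read. The compounds shown leave open at what concentration any of them would become toxic to these cells.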